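Propyl in Place of Cyclopropyl on the Ring Nitrogen

The compounds below may be only part of what the source reports. "The series", "measured", "known", "first", "only" and "open" are said of these compounds alone.

Three compounds sharing one core have been measured in a functional assay on DU-145 cells (Homo sapiens) for inhibition, read by trypan blue exclusion, with a stated time of 72 h; a higher number here means a weaker inhibitor, a lower number a stronger inhibitor:

compound 1 `Cn1c(=O)c(S(=O)(=O)c2ccc(Cl)cc2)cc2cnc(Nc3ccc4[nH]ccc4c3)nc21` gives 250 nM
compound 2 `O=c1c(S(=O)(=O)c2ccc(F)cc2F)cc2cnc(Nc3ccc4[nH]ccc4c3)nc2n1C1CC1` gives 500 nM
compound 3 `Cn1c(=O)c(S(=O)(=O)Nc2ccc(F)cc2F)cc2cnc(Nc3ccc4[nH]ccc4c3)nc21` gives 5000 nM

Compound 2 stands second highest of the three numbers in this assay. Its nearest neighbour is compound 1, a gap that lies within the usual scatter of such measurements, and its furthest is compound 3, a gap that lies beyond it. Compound 1 and compound 2 differ from each other in more than one place, so their two values show only that they sit within the scatter of each other.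

Compound 4 `CCCn1c(=O)c(S(=O)(=O)c2ccc(F)cc2F)cc2cnc(Nc3ccc4[nH]ccc4c3)nc21` differs from compound 2 in a single place: propyl in place of cyclopropyl on an aromatic nitrogen. Among the measured compounds shown here, the one step measured so far, a 20-fold higher number from compound 1 to compound 3 (1.30 log units; beyond the scatter), concerns the group on the sulfonyl sulfur and leaves the substituent on the aromatic nitrogen untouched, so it does not bear on this change. For the measured compounds named here, no measured pair among the three compounds isolates a change at that position. With nothing to point either way, compound 4 is expected to give a number close to that of compound 2, with a step of no change at the digits printed from compound 2 to compound 4 (within the scatter) that should stay within the scatter. Compound 4 is therefore estimated at 500 nM in this assay, in a range from 200 nM to 1500 nM.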

Compound 4, half-maximal inhibitory concentration: 1000 nM
For compound 4 the middle estimate is 2.0-fold (0.30 log units) below the measured one; the measured number falls inside the stated range.
By their numbers in this assay, from the lowest: compounds 1, 2 and 4 (each within the scatter of the next, the first and the last beyond it); then compound 3.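

Among the compounds shown here, the first direct reading at this position comes from this assay, where propyl in place of cyclopropyl on the aromatic nitrogen gives a 2.0-fold higher number from compound 2 to compound 4 (0.30 log units; within the scatter). This assay therefore does not separate the open chain from the three-membered carbon ring, at least with the (2,4-difluorophenyl)sulfonyl group on the shared core: the two substituents have 3 heavy atoms each, and the ring can be opened with the value staying within the scatter. No measurement is at hand that would explain this result or describe how the two groups behave.

As far as these compounds go, the finding rests on a single pair, so it remains open whether the same holds when the sulfonyl sulfur carries the 4-chlorophenyl group of compound 1 or the (2,4-difluorophenyl)amino group of compound 3. From the compounds shown here alone, it also remains open how this assay responds to substituents on the aromatic nitrogen that differ more from these two, such as a longer chain like hexyl, a benzyl group, or a short chain ending in an amine or a carboxylic acid.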